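The source may hold more compounds than are shown below. What is called first, only, known or untested is meant among the compounds shown, and "the series" means these compounds.

Compound 1 `COc1ccc(S(=O)(=O)N2CCc3cccc(-c4ccc([N+](=O)[O-])cc4)c32)cc1`: 51.8 nM
Compound 2 `COc1ccc(S(=O)(=O)n2ccc3cccc(-c4ccc(C#N)cc4)c32)cc1`: 164 nM

Among the compounds with values here, in a functional assay on HT-29 cells (Homo sapiens) for inhibition, with a stated time of 72 h (on this read-out lower numbers stand for stronger inhibition and higher numbers for weaker inhibition), compound 1 has the lower of the two numbers so far, and its gap to compound 2 lies beyond the scatter. Compound 3 `COc1ccc(S(=O)(=O)N2CCc3cccc(-c4ccccc4)c32)cc1` keeps the core of compound 1 but carries hydrogen in place of nitro on an aromatic carbon, para to a large group (hydrogen in place of nitro on an aromatic carbon). Within the data shown here, no measured pair shows this change alone, so any forecast is a judgement. The estimated change is a 2.3-fold higher number from compound 1 to compound 3 (0.36 log units; beyond the scatter) and is expected to run toward weaker inhibition, slightly beyond the scatter. For compound 3 the expected value is 120 nM with an estimated range from 35 nM to 400 nM in this assay.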

Compound 3, half-maximal inhibitory concentration: 96.5 nM
Beside the measured number, compound 3's estimate is 1.2-fold (0.09 log units) above it; measured number inside the range.
By their numbers in this assay, from the lowest: compounds 1, 3 and 2 (each within the scatter of the next, the first and the last beyond it).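

With the core of compound 1 held fixed, the swap of 4-nitrophenyl to phenyl gives a 1.9-fold higher number from compound 1 to compound 3 (0.27 log units; within the scatter) in this assay. At this position, then, the nitro group is not needed for a number in this range, since the two compounds cannot be told apart from the usual scatter. No outside measurement bears on this result, so it comes with no explanation. Going by these compounds, whether an amine or a carboxylic acid in the same place would also stay within the scatter of compound 3 remains open.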